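Changing the Aryl Group on the Amide Carbonyl

The source may report more compounds than this note shows. Statements on the series, on what has been measured and on what is new or still open speak of the compounds shown alone.

Compound 1 `O=C(NC[C@@H]1C[C@@H]2C=C[C@@H]1C2)NS(=O)(=O)N1CCC(CCNC(=O)c2cnsc2)CC1` gives 14% in a functional assay on the whole organism (blood) with Rattus norvegicus as the target, with stated times of 24 h and 1 h, at a dose of 15 mg/kg by the intraperitoneal route (a higher number here means a stronger effect of the compound at the dose given, a lower number a weaker effect), the lowest of the three numbers measured, though compound 2 `Cn1cc(C(=O)NCCC2CCN(S(=O)(=O)NC(=O)NC3CCCCC3)CC2)c(=O)n(C)c1=O` gives 15% and compound 3 `CSc1ccc(C(F)(F)F)cc1C(=O)NCCC1CCN(S(=O)(=O)NC(=O)NC2CCCCC2)CC1` gives 24%, both within the scatter of compound 1. Compound 4 `COc1ccc(C(=O)NCCC2CCN(S(=O)(=O)NC(=O)NC[C@@H]3C[C@@H]4C=C[C@@H]3C4)CC2)cn1` differs from compound 1 in one place: 6-methoxypyridin-3-yl in place of 1,2-thiazol-4-yl on a carbonyl carbon. For the measured compounds named here, the only measured step on the same carbonyl carbon, a number 9 percentage points higher from compound 2 to compound 3 (within the scatter), also exchanged one aromatic group for another and stayed within the scatter. On that basis no step beyond the scatter is expected in this assay for compound 4, whose result is estimated at 17% with a range from 5% to 32%. The step this estimate implies, a number 3 percentage points higher from compound 1 to compound 4 (within the scatter), is expected to be small.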

Compound 4, a percentage reported as activity, at one dose (the size of the read-out at that dose, not a potency): 32%
Beside the measured number, compound 4's estimate is 15 percentage points below it, and the stated range covers the measured number.
By their numbers in this assay, from the lowest: compounds 1, 2, 3 and 4 (each within the scatter of the next, the first and the last beyond it).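

For the compounds shown here, the exchange of 1,2-thiazol-4-yl for 6-methoxypyridin-3-yl on this carbonyl carbon gives the only step beyond the scatter at this position in this assay, a number 18 percentage points higher from compound 1 to compound 4 (beyond the scatter). The position can therefore shift the read-out at the dose given, which the exchange of groups between compound 2 and compound 3 did not show. No measurement of any property of the two groups bears on this result.

From the compounds shown here alone, it remains open whether the step belongs to the methoxy group or to the six-membered ring. A plain pyridin-3-yl or a 6-ethoxypyridin-3-yl on the same carbonyl carbon would help separate the two.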